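Benzyl-Ethyl Amide in Place of Aryloxymethyl on a Shared Core

This account rests on a few compounds, and the source may have more. Where it says the series, first, only, none or still open, it means among the compounds named here.

Of the compounds shown here, three of one series have been tested in an assay on HEK293 cells for displacement of a labelled ligand from Melanocortin receptor 4 (Homo sapiens); a lower number here means a stronger inhibitor, a higher number a weaker inhibitor. Compound 1 `CC(C)C[C@H](N)c1cc(C(F)(F)F)ccc1N1CCN(C(=O)CCC(N)=O)CC1` gives only a limit in this assay, > 10000 nM (the limit of > 10000 nM in this assay, at which 1 of the 3 values shown sits). Compound 2 `COc1ccc(OCC(=O)N2CCN(c3ccc(C(F)(F)F)cc3[C@@H](N)CC(C)C)CC2)cc1` gives 3800 nM, and compound 3 `CC(C)C[C@H](N)c1cc(C(F)(F)F)ccc1N1CCN(C(=O)C(C)Cc2ccc(Cl)cc2)CC1` gives 47 nM. Of the two numbers shown, compound 2 stands highest; its nearest neighbour is compound 3, and that step is large: an 81-fold lower number from compound 2 to compound 3 (1.91 log units; beyond the scatter). The steps from the limit run the same way, an at least 2.6-fold lower number from compound 1 to compound 2 (0.42 log units; beyond the scatter) and an at least 210-fold lower number from compound 1 to compound 3 (2.32 log units; beyond the scatter).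

Compound 4 `COc1ccc(CC(C)C(=O)N2CCN(c3ccc(C(F)(F)F)cc3[C@@H](N)CC(C)C)CC2)cc1F` has not yet been measured. It differs from compound 2 in one place: 1-(3-fluoro-4-methoxybenzyl)ethyl in place of (4-methoxyphenoxy)methyl on a carbonyl carbon. The step from compound 2 to compound 3 bears directly on this change, since there too (4-methoxyphenoxy)methyl on the carbonyl carbon gave way to a 1-(benzyl)ethyl group, in that case 1-(4-chlorobenzyl)ethyl. Within the data shown here, the group entering compound 4 shares that arrangement and differs only in what the aromatic ring carries, and no measured compound here separates a 3-fluoro-4-methoxy ring from a 4-chloro ring. A large step downward, of about the size seen for compound 3, is therefore expected. Compound 4 is expected to give about 100 nM in this assay, between 25 nM and 400 nM. That estimate means an expected step of a 38-fold lower number from compound 2 to compound 4 (1.58 log units; beyond the scatter).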

Compound 4, inhibition constant: 200 nM
Compound 4: the middle estimate sits 2.0-fold (0.30 log units) below what was measured; low and high end bracket the measured number.
By their numbers in this assay, from the lowest: compound 3; then compound 4; then compound 2. At a limit, above all of these: compound 1.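

In this assay, the gain on leaving (4-methoxyphenoxy)methyl does not rest on the 4-chloro ring alone: with 1-(3-fluoro-4-methoxybenzyl)ethyl on the carbonyl carbon the step is still large, a 19-fold lower number from compound 2 to compound 4 (1.28 log units; beyond the scatter). What the aromatic ring carries also counts, though less than the change of the group as a whole, and swapping 4-chlorophenyl for 3-fluoro-4-methoxyphenyl gives a modest step, a 4.3-fold higher number from compound 3 to compound 4 (0.63 log units; beyond the scatter). The step from the limit is only a bound, an at least 50-fold lower number from compound 1 to compound 4 (1.69 log units; beyond the scatter), and the value it starts from is a limit and not a number: the limit of > 10000 nM in this assay, at which 1 of the 4 values shown sits.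

The compounds shown do not tell whether the fluorine or the methoxy accounts for the gap between the two rings, and a 4-methoxybenzyl or a 3-fluorobenzyl version of the group would separate the two. Nor do they tell whether the large gain comes from the branching methyl on the chain or from the loss of the oxygen link, a question that an unbranched 2-(4-methoxyphenyl)ethyl group on the same carbonyl carbon would address.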